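Swapping Nitro for Fluoro: Expected Effect on Cell Toxicity

The source may report more compounds than this note shows. Statements on the series, on what has been measured and on what is new or still open speak of the compounds shown alone.

Three close relatives sharing one core have been tested for how strongly they harm cultured cells in an ADME assay on Vero cells (Chlorocebus sabaeus) for cytotoxicity, read by MTT assay, with a stated time of 72 h; on this read-out higher numbers stand for lower toxicity in this test and lower numbers for higher toxicity in this test. Compound 1 `N/C(=N/NC(CC(=O)c1ccc(-n2ccnc2)cc1)c1ccc(Cl)cc1Cl)c1ccccn1` gives 27800 nM. Compound 3 `N/C(=N/NC(CC(=O)c1ccc(-n2ccnc2)cc1)c1ccc([N+](=O)[O-])cc1)c1ccccn1` gives 23100 nM. Compound 2 `N/C(=N/NC(CC(=O)c1ccc(-n2ccnc2)cc1)c1cccc([N+](=O)[O-])c1)c1ccccn1` gives 28700 nM, the highest of the three numbers, yet it sits within the usual scatter of both others: the step of a 1.0-fold higher number from compound 1 to compound 2 (0.01 log units; within the scatter) and the step of a 1.2-fold lower number from compound 2 to compound 3 (0.09 log units; within the scatter) are both small, as is the step of a 1.2-fold lower number from compound 1 to compound 3 (0.08 log units; within the scatter). In short, changing the aryl group on this chain carbon has so far made no difference that can be told from measurement noise.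

Compound 4 `N/C(=N/NC(CC(=O)c1ccc(-n2ccnc2)cc1)c1cccc(F)c1)c1ccccn1` has not been measured. It differs from compound 2 by fluoro in place of nitro on an aromatic carbon; cut one bond further out, the change reads 3-nitrophenyl to 3-fluorophenyl. All three measured steps alter the same aryl group, and none of them leaves the scatter, so no step beyond the scatter is expected in this assay either. The expected value for compound 4 is 27000 nM, with a range from 14000 nM to 52000 nM. This estimate means an expected step of a 1.1-fold lower number from compound 2 to compound 4 (0.03 log units; within the scatter).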

Compound 4, half-maximal cytotoxic concentration: 26500 nM
Compound 4: the middle estimate sits 1.0-fold (0.01 log units) above what was measured; the measured number falls inside the stated range.
By their numbers in this assay, from the lowest: compounds 3, 4, 1 and 2 (each within the scatter of the next).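

Going by these compounds alone, this is the first step here that swaps a single group while its place on the ring stays the same: nitro, with 3 heavy atoms and 2 hydrogen-bond acceptors, gives way to fluoro, with 1 heavy atom and 0 hydrogen-bond acceptors, and this assay shows a 1.1-fold lower number from compound 2 to compound 4 (0.03 log units; within the scatter) as the result. The new 3-fluorophenyl compound also stays level with the two other aryl variants, with a 1.1-fold higher number from compound 3 to compound 4 (0.06 log units; within the scatter) and a 1.0-fold lower number from compound 1 to compound 4 (0.02 log units; within the scatter) as its remaining steps, so a fourth aryl group, carrying neither nitro nor chlorine, still gives no difference that can be told from noise. Nothing available explains why the read-out stays so flat across these changes.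

The compounds shown leave open whether this flat picture would survive a group of another kind on the same aromatic carbon, such as an amine or a carboxylic acid. They also leave open what would happen if the aryl group on the chain carbon gave way to something other than a substituted phenyl ring, such as a plain longer chain of carbon atoms.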